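A Methyl Added Where Both Neighbours Sit at the Limit

A few compounds are considered here, and "the series" means these few. Any claim that something is new, unique, unknown or untested is made for them only; others in the source may bear on it.

Compound 1 `COCn1c(CC(O)(COCc2ccccc2)COCc2ccccc2)cc(=O)[nH]c1=O` and compound 2 `COCn1c(CC(COCc2ccccc2)COCc2ccccc2)cc(=O)[nH]c1=O` share one core. In a functional assay on SW-620 cells (Homo sapiens) for antiproliferative activity, read by MTT assay, with a stated time of 72 h (on this read-out lower numbers stand for stronger inhibition and higher numbers for weaker inhibition), compound 1 gives > 100000 nM, a limit of the assay rather than a number. In this assay compound 2 gives > 100000 nM, also a limit. The step that the two limits leave unreadable from compound 1 to compound 2 is thus unreadable, and compound 2 stands at the limit of > 100000 nM in this assay, at which 2 of the 2 values shown sit. Compound 3 `COCn1c(CC(COCc2ccccc2)COCc2ccccc2)c(C)c(=O)[nH]c1=O` differs from compound 2 by methyl in place of hydrogen on an aromatic carbon. For the measured compounds named here, no measured step bears on this change, so no direction can be drawn. Compound 3 is expected to give 100000 nM, between 30000 nM and 300000 nM, an estimated step of a number no higher from compound 2 to compound 3 (the limit leaves the size open).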

Compound 3, half-maximal inhibitory concentration: 72100 nM
For compound 3 the middle estimate is 1.4-fold (0.14 log units) above the measured one, within the range that was stated.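

In this assay, for the compounds shown here, methyl on this aromatic carbon gives the first step with a readable floor: an at least 1.3-fold lower number from compound 2 to compound 3 (0.14 log units; that floor lies within the scatter). Compound 3 is also the first compound shown to return a number rather than a limit. The true size of the step stays open, since the floor lies within the scatter and the starting point is only a limit: the limit of > 100000 nM in this assay, at which 2 of the 3 values shown sit.

On these data alone, what an ethyl group, a longer chain or an amine on this same aromatic carbon would give remains open.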